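The source may hold more compounds than are shown below. What is called first, only, known or untested is meant among the compounds shown, and "the series" means these compounds.

Within the data shown here, in a physicochemical assay for lipophilicity, measured as octanol-water partition (on this read-out higher numbers stand for higher lipophilicity and lower numbers for lower lipophilicity), compound 2 `CC1=C(C(=O)OCc2ccccn2)C(c2ccc(Cl)cc2)C2=C(CCCC2=O)N1` gives 2.24, the higher of the two numbers so far, while compound 1 `CC1=C(C(=O)OCc2ccccn2)C(c2ccc(O)cc2)C2=C(CCCC2=O)N1` gives 1.58. Compound 3 `CC1=C(C(=O)OCc2ccccn2)C(c2cccs2)C2=C(CCCC2=O)N1` alters a different group, on a saturated ring carbon: thiophen-2-yl in place of 4-chlorophenyl on a saturated ring carbon. Among the measured compounds shown here, the one measured step, a number 0.66 log units higher from compound 1 to compound 2 (beyond the scatter), put chloro in place of hydroxy on an aromatic carbon. For the measured compounds named here, it bears on this change only in part, as chlorine leaves here too, and no measured step swaps a whole aromatic ring. The expected step is modest and downward, a number 0.49 log units lower from compound 2 to compound 3 (beyond the scatter). Compound 3 is estimated at 1.75, with an expected range of 1.3 to 2.15.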

Compound 3, partition coefficient: 1.77
Beside the measured number, compound 3's estimate is 0.02 log units below it, within the range that was stated.
By their numbers in this assay, from the lowest: compounds 1 and 3 (each within the scatter of the next); then compound 2.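

In this assay, this position takes a change of the whole aromatic ring, not only of the group on it. Thiophen-2-yl in place of 4-chlorophenyl gives a number 0.47 log units lower from compound 2 to compound 3 (beyond the scatter), whereas thiophen-2-yl in place of 4-hydroxyphenyl gives a number 0.19 log units higher from compound 1 to compound 3 (within the scatter), so the thiophene compound and the phenol cannot be separated on this read-out. Nothing measured here explains either step. Still open, going by these compounds, is how a ring without aromatic character, such as cyclohexyl, or a carboxylic acid or an amine on a chain would behave on this saturated ring carbon.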